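The source may report more compounds than this note shows. Statements on the series, on what has been measured and on what is new or still open speak of the compounds shown alone.

Compounds measured so far:
Compound 1 `CONC(=S)N/N=C1\C(=O)N(CN2CCN(c3c(F)cc4c(=O)c(C(=O)O)cn(C5CC5)c4c3OC)CC2C)c2ccc(F)cc21`: 171000 nM
Compound 2 `CONC(=S)N/N=C1\C(=O)N(CN2CCN(c3c(F)cc4c(=O)c(C(=O)O)cn(C5CC5)c4c3OC)CC2C)c2ccc(Cl)cc21`: 164000 nM

For the measured compounds named here, in an ADME assay on MT4 cells (Homo sapiens) for cytotoxicity, read by spectrophotometry, with a stated time of 5 days (a higher number here means that more compound is tolerated, a lower number that less compound is tolerated), compound 2 gives 164000 nM and stands level with compound 1, the only other compound measured so far, at 171000 nM on the same scale. The two values lie within the scatter of each other.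

The next compound, compound 3 `CONC(=S)N/N=C1\C(=O)N(CN2CCN(c3c(F)cc4c(=O)c(C(=O)O)cn(C5CC5)c4c3OC)CC2C)c2ccc(C)cc21`, keeps the shared core of compound 2 and differs in one group, with methyl in place of chloro on an aromatic carbon. Going by the values given here, only one measured step bears on this. It exchanges one substituent for another on that same aromatic carbon, chloro in place of fluoro, and its size is a 1.0-fold lower number from compound 1 to compound 2 (0.02 log units; within the scatter) in this assay. Among the compounds with values here, no measured compound carries methyl there, so this support is thin, and the range has to stay wide.

On this single step, no shift beyond the scatter is expected. The expected step is a 1.0-fold lower number from compound 2 to compound 3 (0.01 log units; within the scatter) in this assay by this estimate. For compound 3 the estimated value is 160000 nM, with an expected range from 100000 nM to 250000 nM as the estimate.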

Compound 3, half-maximal cytotoxic concentration: 154000 nM
Beside the measured number, compound 3's estimate is 1.0-fold (0.02 log units) above it; the range from low to high includes it.
By their numbers in this assay, from the lowest: compounds 3, 2 and 1 (each within the scatter of the next).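

In this assay, for the compounds shown here, the aromatic carbon has now carried three different substituents, and methyl is the first of them that is not a halogen. The step of a 1.1-fold lower number from compound 2 to compound 3 (0.03 log units; within the scatter) lies within the scatter, as does the step of a 1.1-fold lower number from compound 1 to compound 3 (0.05 log units; within the scatter), so the absence of a separable difference seen between fluoro and chloro now extends to methyl, for these three compounds only. Nothing available here accounts for this flat result.

The compounds shown leave open whether an amine, a carboxylic acid or a longer chain on that same aromatic carbon would also stay within the scatter, since fluoro, chloro and methyl are the only groups seen there. They also leave open whether changes elsewhere on the shared core would leave this assay's read-out just as undisturbed, because all three compounds keep everything outside this one substituent identical.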